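Ethoxy for Methyl on the Fused Ring of Compound 3

The source may report more compounds than this note shows. Statements on the series, on what has been measured and on what is new or still open speak of the compounds shown alone.

Three close relatives of one shared core have been tested in a toxicity assay on HepG2 cells (Homo sapiens) for inhibition, read by CellTiter-Glo, with a stated time of 48 h; a lower number here means a stronger inhibitor, a higher number a weaker inhibitor. Compound 1 `COc1ccc2c(OCC(=O)Nc3cc(C)cc(C)c3)cc(C)nc2c1` gives 50100 nM; compound 2 `Cc1cc(C)cc(NC(=O)COc2cc(C)nc3ccc(F)cc23)c1` gives 63100 nM; and compound 3 `Cc1cc(C)cc(NC(=O)COc2cc(C)nc3ccc(C)cc23)c1` gives 15900 nM, the lowest of the three numbers, with compound 1 nearest and compound 2 furthest away. Within the data shown here, the one measured step that changes a single place is a 4.0-fold lower number from compound 2 to compound 3 (0.60 log units; beyond the scatter), and it touches the same aromatic carbon that is now changed again.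

Compound 4 `CCOc1ccc2nc(C)cc(OCC(=O)Nc3cc(C)cc(C)c3)c2c1` is not yet measured. It differs from compound 3 by ethoxy in place of methyl on an aromatic carbon. Among the measured compounds shown here, no measured step swaps a methyl for an ethoxy, but the only compound carrying an oxygen-linked group at this carbon, compound 1 with its methoxy, shows a higher number than compound 3 does. Compound 4 is therefore expected to move back toward that higher number, an expected step of a 2.2-fold higher number from compound 3 to compound 4 (0.34 log units; beyond the scatter) in this assay. The estimate for compound 4 is 35000 nM, within a range from 12000 nM to 100000 nM.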

Compound 4, half-maximal inhibitory concentration: > 100000 nM
Compound 4 was reported as a limit; the forecaster's own chance of this, stated with the estimate: 10%; middle value at least 2.8-fold (0.45 log units) away from the limit.
By their numbers in this assay, from the lowest: compound 3; then compounds 1 and 2 (each within the scatter of the next). At a limit, above all of these: compound 4.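

In this assay, putting an oxygen-linked chain on this aromatic carbon gives an at least 6.2-fold higher number from compound 3 to compound 4 (0.79 log units; beyond the scatter), so among the four compounds the methyl of compound 3 still gives the strongest inhibition. Compound 4 is reported only as a limit, not as a number: the limit of > 100000 nM in this assay, at which 1 of the 4 values shown sits. The other new comparison, an at least 1.5-fold higher number from compound 2 to compound 4 (0.19 log units; that floor lies within the scatter), has a floor that lies within the scatter, so these data cannot place ethoxy and fluoro in order at this carbon.

On these data alone, how far compound 4 really lies from the other compounds stays open, since a limit gives no exact value to compare. Also open, as far as these compounds go, is whether a different group on this carbon, such as an amine, a hydroxyl or a plain ethyl chain without the oxygen, would stay close to the methyl of compound 3 or move away from it.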